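This account rests on a few compounds, and the source may have more. Where it says the series, first, only, none or still open, it means among the compounds named here.

Three compounds have been measured in a functional assay for inhibition, tested at 20 ug/mL; on this read-out lower numbers stand for a weaker effect and higher numbers for a stronger effect at the one concentration tested:

compound 1 `COc1cc(-c2cc(-c3cc(C(C)C)c(O)cc3C)[nH]c(=O)c2C#N)cc(OC)c1OC` gives 35%
compound 2 `COc1ccc(-c2cc(-c3cc(C(C)C)c(O)cc3C)[nH]c(=O)c2C#N)c(OC)c1` gives 27%
compound 3 `COc1cc(-c2cc(-c3cc(C(C)C)c(O)cc3C)[nH]c(=O)c2C#N)ccc1O` gives 26%

Compound 3 carries the lowest of the three numbers, yet the step of a number 1 percentage points lower from compound 2 to compound 3 (within the scatter) lies within the scatter, and the gap from compound 3 to compound 1 does as well, so the three values cannot be separated from one another in this assay.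

Compound 4 `COc1ccc(-c2cc(-c3cc(C(C)C)c(O)cc3C)[nH]c(=O)c2C#N)cc1OC` differs from compound 3 by methyl in place of hydrogen on an oxygen on an aromatic ring. Among the compounds with values here, the only one-place step measured, a number 1 percentage points lower from compound 2 to compound 3 (within the scatter), touched the same ring with a larger change and moved nothing beyond the scatter. Compound 4 is therefore expected to give 30% in this assay, between 15% and 45%. The step of a number 4 percentage points higher from compound 3 to compound 4 (within the scatter) is thus estimated to stay within the scatter, in neither direction.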

Compound 4, a percentage reported as inhibition, at one concentration (the size of the read-out at that concentration, not a potency): 25%
Compound 4: middle estimate off by 5 percentage points, on the high side; the range from low to high includes it.
By their numbers in this assay, from the lowest: compounds 4, 3, 2 and 1 (each within the scatter of the next).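

In this assay, methyl on the oxygen of the aromatic ring, turning hydroxy into methoxy, stays within the scatter (a number 1 percentage points lower from compound 3 to compound 4 (within the scatter)), so the free hydroxy shows no separable contribution at this position. The 3,4-dimethoxyphenyl compound also cannot be separated from its 2,4-dimethoxyphenyl partner (a number 2 percentage points lower from compound 2 to compound 4 (within the scatter)) or from the compound with one further methoxy (a number 10 percentage points lower from compound 1 to compound 4 (within the scatter)). Nothing available explains these results. Still open, going by these compounds, is whether a longer chain on this oxygen, such as benzyl, would shift the number beyond the scatter. The same holds for an amine or a carboxylic acid in place of the hydroxy.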